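Hydroxy in Place of Chloro: An Expected Step

The source may report more compounds than this note shows. Statements on the series, on what has been measured and on what is new or still open speak of the compounds shown alone.

Compound 1 `O=C(/C=C\Nc1ccc(O)cc1)c1cn(-c2ccccc2)nc1-c1ccccc1`: 4290 nM
Compound 2 `O=C(/C=C\Nc1ccc(Cl)cc1)c1cn(-c2ccccc2)nc1-c1ccc(F)cc1`: 8900 nM

Of the compounds shown here, two have been measured in a functional assay on U-87MG ATCC cells (Homo sapiens) for antiproliferative activity, read by MTT assay, with a stated time of 48 h; on this read-out higher numbers stand for weaker inhibition and lower numbers for stronger inhibition. Compound 1 gives 4290 nM, and compound 2 gives 8900 nM. Of the two numbers, compound 2 stands highest, and its nearest neighbour is compound 1, whose number is lower by a margin that lies beyond the usual scatter. Among the measured compounds shown here, the two compounds differ in more than one place, so no single step between them can be read off.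

Compound 3 `O=C(/C=C\Nc1ccc(O)cc1)c1cn(-c2ccccc2)nc1-c1ccc(F)cc1` has not yet been measured. It differs from compound 2 in one place only: hydroxy in place of chloro on an aromatic carbon, on an aromatic carbon of a six-membered aromatic ring of carbon only, para to a large group. Compound 3 otherwise keeps everything that compound 2 carries, including the 4-fluorophenyl group.

Because compound 1, which carries the same hydroxy group, gives 4290 nM, a step downward from compound 2 to compound 3 is expected in this assay, estimated as a 1.8-fold lower number from compound 2 to compound 3 (0.25 log units; within the scatter). Compound 3 is expected to give about 5000 nM, with a plausible range from 1500 nM to 15000 nM.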

Compound 3, half-maximal inhibitory concentration: 4700 nM
Beside the measured number, compound 3's estimate is 1.1-fold (0.03 log units) above it, and the stated range covers the measured number.
By their numbers in this assay, from the lowest: compounds 1, 3 and 2 (each within the scatter of the next, the first and the last beyond it).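

In this assay, among the compounds shown here, hydroxy in place of chloro on an aromatic carbon, para to a large group, gives a 1.9-fold lower number from compound 2 to compound 3 (0.28 log units; within the scatter), so this swap, seen here on its own for the first time, stays within the usual scatter of repeated measurements. Compound 3 also pairs with compound 1 through a second single difference, fluoro in place of hydrogen on an aromatic carbon, which gives a 1.1-fold higher number from compound 1 to compound 3 (0.04 log units; within the scatter) and likewise stays within the scatter, so in compounds carrying the 4-hydroxyphenyl group the fluoro leaves no difference that these numbers can separate from noise. No measurement available here accounts for the size of either step.

The compounds shown leave open whether another group at this place, such as an amine, a methoxy group or a carboxylic acid, would also stay within the scatter of compound 3 or would give a step beyond it. They also leave open whether fluoro in place of hydrogen would give a similar step in a compound that carries the 4-chlorophenyl group instead.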